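Swapping the ring-bearing group of compound 3 for propanoylamino

The source may report more compounds than this note shows. Statements on the series, on what has been measured and on what is new or still open speak of the compounds shown alone.

Compound 1 (`Nc1ccc(CNC(=O)Nc2ccc(CN3C(=O)c4ccccc4C3=O)cc2)cn1`) gives 3.1 nM in a functional assay on COR-L23 cells (Homo sapiens) for antiproliferative activity, read by CellTiter-Glo, with a stated time of 72 h (a higher number here means a weaker inhibitor, a lower number a stronger inhibitor), and compound 2 (`C[C@@H](c1ccc(NC(=O)N2CC(c3cccnc3)C2)cc1)N1Cc2ccccc2C1=O`) gives 8 nM there, while compound 3 (`C[C@@H](c1ccc(NC(=O)N2CC(c3ccc(N)nc3)C2)cc1)N1Cc2ccccc2C1=O`) gives 19 nM as the highest number of the three. Compound 4 (`CCC(=O)N[C@@H](C)c1ccc(NC(=O)N2CC(c3ccc(N)nc3)C2)cc1`) changes compound 3 in one place (a group of 5 heavy atoms (3 carbon, 1 nitrogen, 1 oxygen; no ring) in place of a group of 10 heavy atoms (8 carbon, 1 nitrogen, 1 oxygen; one five-membered non-aromatic ring with 1 hetero atom, one six-membered aromatic ring of carbon only), on a saturated chain carbon bound to an aromatic carbon and a saturated chain carbon). Within the data shown here, the only measured step (a 2.4-fold higher number from compound 2 to compound 3 (0.38 log units; beyond the scatter)) was modest, but it concerns a different change, amino in place of hydrogen on an aromatic carbon. Among the measured compounds shown here, no measured compound tests the propanoylamino group, so that step gives no size to carry over and the expectation stays loose. Since a smaller group with no ring enters and compound 3 stands at 19 nM with its larger group in place, a higher number is expected in this assay for compound 4, meaning a weaker inhibitor. The estimated size of this change (a 7.9-fold higher number from compound 3 to compound 4 (0.90 log units; beyond the scatter)) is a rough one. Compound 4 is estimated at 150 nM within an expected range from 30 nM to 800 nM for now.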

Compound 4, half-maximal inhibitory concentration: 120 nM
Compound 4: middle estimate off by 1.3-fold (0.10 log units), on the high side; the measured number falls inside the stated range.
By their numbers in this assay, from the lowest: compound 1; then compound 2; then compound 3; then compound 4.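

In this assay, among these compounds, the step of a 6.3-fold higher number from compound 3 to compound 4 (0.80 log units; beyond the scatter) is the first measured change at this saturated chain carbon, and it shows that the group held there matters to the antiproliferative read-out. The change is not all-or-nothing: with propanoylamino in place of the larger two-ring group, compound 4 still gives a number of 120 nM. The two groups differ in several ways at once, including size, ring content and hydrogen-bond donor count, so this single step cannot separate their contributions, and no accompanying measurement explains the rise in the number.

The compounds shown leave open whether a benzoylamino group, which restores an aromatic ring on the same amide link, would recover the lost ground. They also leave open how a shorter acetylamino group or a longer butanoylamino chain would compare with propanoylamino at this carbon.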